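Swapping nitrile for methylsulfonyl: the expected acid dissociation shift

The compounds below may be only part of what the source reports. "The series", "measured", "known", "first", "only" and "open" are said of these compounds alone.

Measured in a physicochemical assay for acid dissociation, using potentiometric titration:
Compound 1 `C[C@@]1(c2cc(-c3ccc(Cl)cn3)ccc2F)CCC2(CC2)C(N)=N1`: > 11
Compound 2 `COc1cnc(-c2ccc(F)c([C@]3(C)CC[C@@](C)(C#N)C(N)=N3)c2)cn1`: 8.5

The entry for compound 1 (> 11) is a limit of the assay, not a number. Within the data shown here, that leaves compound 2 (8.5) with the only actual number.

Compound 3 `COc1cnc(-c2ccc(F)c([C@]3(C)CC[C@@](C)(S(C)(=O)=O)C(N)=N3)c2)cn1` carries methylsulfonyl in place of cyano on a saturated ring carbon, next to the ring atom that bears an amino group (methylsulfonyl in place of cyano on a saturated ring carbon). Among the measured compounds shown here, no measured pair shows this swap, so the expectation rests on compound 2 (8.5) alone. A small fall in the number is expected (a number 0.50 log units lower from compound 2 to compound 3 (beyond the scatter)), and it may not clear the usual scatter. The estimated value for compound 3 is 8 (expected range 7.2 to 8.8).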

Compound 3, acid dissociation constant: 8.4
Compound 3: middle estimate off by 0.40 log units, on the low side; low and high end bracket the measured number.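

In this assay, putting methylsulfonyl in place of cyano on this saturated ring carbon gives a number 0.10 log units lower from compound 2 to compound 3 (within the scatter). On this core, then, the two groups cannot be told apart by this read-out, although methylsulfonyl brings more heavy atoms and hydrogen-bond acceptors. The step compares two actual numbers because neither compound sits at the limit of the assay: the limit of > 11 in this assay, at which 1 of the 3 values shown sits.

As far as these compounds go, it remains open whether a different group on this carbon, such as an amine or a carboxylic acid, would move the number beyond the scatter.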